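Chloro-diene indolyl ketones: trimethoxyphenyl analogue pending

This account rests on a few compounds, and the source may have more. Where it says the series, first, only, none or still open, it means among the compounds named here.

Measured so far:
compound 1, `COc1ccc2[nH]cc(C(=O)/C(C#N)=C/C=C(\Cl)c3ccc(OC)c(OC)c3)c2c1`, > 100000 nM (a limit)
compound 2, `COc1ccc(/C(Cl)=C/C=C(\C#N)C(=O)c2c[nH]c3ccc(OC)cc23)cc1`, > 100000 nM (a limit)
compound 3, `COc1ccc(/C(Cl)=C/C=C(\C#N)C(=O)c2c(C)[nH]c3ccccc23)cc1OC`, 93000 nM

In a functional assay on MCF7 cells (Homo sapiens) for cytotoxicity, read by sulforhodamine B assay, with a stated time of 48 h (on this read-out lower numbers stand for stronger inhibition of growth and higher numbers for weaker inhibition of growth), compound 1 returns only a limit, > 100000 nM. Compound 2 likewise returns a limit, > 100000 nM. Among the measured compounds shown here, compound 3 gives 93000 nM, the single number in the set. The step that the two limits leave unreadable from compound 2 to compound 1 is methoxy in place of hydrogen on an aromatic carbon; both of its ends sit at the limit of > 100000 nM in this assay, at which 2 of the 3 values shown sit, so its size cannot be read. The difference between the cores of compound 2 and compound 3 is not broken down here. Compound 4, `COc1cc(/C(Cl)=C/C=C(\C#N)C(=O)c2c(C)[nH]c3ccccc23)cc(OC)c1OC`, carries methoxy in place of hydrogen on an aromatic carbon; this is the same kind of change, the place differing in that it is also meta to a methoxy group. Since the earlier step that the two limits leave unreadable from compound 2 to compound 1 gives no readable size, the expectation for compound 4 rests on compound 3 alone at 93000 nM. Compound 4 is therefore estimated at 80000 nM in this assay, between 30000 nM and 150000 nM. This estimate means a step of a 1.2-fold lower number from compound 3 to compound 4 (0.07 log units; within the scatter).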

Compound 4, concentration for total growth inhibition: 83700 nM
Compound 4: the middle estimate sits 1.0-fold (0.02 log units) below what was measured; the measured number falls inside the stated range.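

In this assay, methoxy in place of hydrogen on an aromatic carbon gives a 1.1-fold lower number from compound 3 to compound 4 (0.05 log units; within the scatter), so on the core of compound 3 this change shows no difference beyond the scatter. Among the compounds shown here, the same kind of change from compound 2 to compound 1, on the other core, cannot be read, as both ends are limits: the limit of > 100000 nM in this assay, at which 2 of the 4 values shown sit. The single readable step therefore does not show whether the change carries over from one core to the other.

The compounds shown leave open what an amine, a carboxylic acid or a longer chain such as ethoxy would give in place of this methoxy on the core of compound 3.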